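A few compounds are considered here, and "the series" means these few. Any claim that something is new, unique, unknown or untested is made for them only; others in the source may bear on it.

Compound 1 `N#Cc1ccc(SCc2ccccc2)cc1` and compound 2 `N#Cc1ccc(SCc2ccc(Cl)cc2)cc1` share one core. In an assay on microsomes for inhibition of Amine oxidase [flavin-containing] B (Homo sapiens), read by fluorescence and spectrophotometry, with a stated time of 20 min (a lower number here means a stronger inhibitor, a higher number a weaker inhibitor), compound 1 gives 1580 nM, and compound 2 gives 531 nM. The change between them, (chloro in place of hydrogen on an aromatic carbon), produced a 3.0-fold lower number from compound 1 to compound 2 (0.47 log units; beyond the scatter). Compound 3 `N#Cc1ccc(Sc2ccccc2)cc1` is built on a different core; the difference between the two cores is not broken down here. In this assay compound 3 gives 11200 nM, the highest number of the three measured compounds. Compound 4 `N#Cc1ccc(Sc2ccc(Cl)cc2)cc1` has not yet been measured. Among the measured compounds shown here, it differs from compound 3 by chloro in place of hydrogen on an aromatic carbon, the same kind of change as the one from compound 1 to compound 2, though the surroundings differ: in compound 2 the chloro sits para to a large group, in compound 4 para to a group of 9 heavy atoms. In this assay, for the measured compounds named here, the expected step is a 3.0-fold lower number from compound 3 to compound 4 (0.48 log units; beyond the scatter), which rests on the single comparable step a 3.0-fold lower number from compound 1 to compound 2 (0.47 log units; beyond the scatter) and on the starting point of compound 3 at 11200 nM; with only one prior example, the uncertainty is wide. Compound 4 is thus estimated at 3700 nM, most likely between 1500 nM and 9000 nM.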

Compound 4, half-maximal inhibitory concentration: 4280 nM
Compound 4: middle estimate off by 1.2-fold (0.06 log units), on the low side, and the stated range covers the measured number.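

In this assay, chloro in place of hydrogen on an aromatic carbon again lowered the number, with a 2.6-fold lower number from compound 3 to compound 4 (0.42 log units; beyond the scatter) on the core of compound 3. The step therefore carried over from the core of compound 1 to this second core with its size intact, the two steps agreeing as closely as repeated measurements could show: the same change on two cores in this assay, a 3.0-fold lower number (0.47 log units; beyond the scatter) from compound 1 to compound 2 and a 2.6-fold lower number (0.42 log units; beyond the scatter) from compound 3 to compound 4, 1.1-fold (0.06 log units) apart, within the scatter of two such steps. This shows transfer for one group at one place on two cores only, and it neither establishes that a third core would respond alike nor explains why the two steps agree.

The compounds shown leave open whether another group at the same place, such as fluoro, methoxy, an amine or a carboxylic acid, would lower the number on both cores by a matching amount. They also leave open how a longer chain in the core would change the number, and whether the chloro step would keep its size there.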